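Dimethylamino to diethylamino on compound 2

The compounds below may be only part of what the source reports. "The series", "measured", "known", "first", "only" and "open" are said of these compounds alone.

Measured in a functional assay on cells (Neutrophil, Homo sapiens) for inhibition, read by transwell migration; on this read-out higher numbers stand for weaker inhibition and lower numbers for stronger inhibition:
compound 1 `CC(=O)c1c(NCCN(C)C)n(-c2ccccc2)c(=S)n(-c2ccccc2)c1=O` gives 6.86 nM
compound 2 `CC(C)OC(=O)c1c(NCCN(C)C)n(-c2ccccc2)c(=S)n(-c2ccccc2)c1=O` gives 0.18 nM

Compound 2 holds the lower of the two numbers. Compound 3 `CCN(CC)CCNc1c(C(=O)OC(C)C)c(=O)n(-c2ccccc2)c(=S)n1-c1ccccc1` carries the change diethylamino in place of dimethylamino on a saturated chain carbon, two bonds along the chain from a nitrogen on an aromatic ring on the same core. Going by the values given here, the only measured step of a 38-fold lower number from compound 1 to compound 2 (1.58 log units; beyond the scatter) lies at a carbonyl carbon, so it does not cover this place, and no measured step does. With no direct evidence, a small move towards a higher number is expected in this assay and it may stay within the scatter. The expected step is a 1.7-fold higher number from compound 2 to compound 3 (0.22 log units; within the scatter) on this estimate. Compound 3 is estimated at 0.3 nM with an expected range of 0.08 nM to 1.2 nM for now.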

Compound 3, half-maximal inhibitory concentration: 0.21 nM
Compound 3: the middle estimate sits 1.4-fold (0.15 log units) above what was measured; the measured number falls inside the stated range.
By their numbers in this assay, from the lowest: compounds 2 and 3 (each within the scatter of the next); then compound 1.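

In this assay, this saturated chain place accepts diethylamino in place of dimethylamino with no change beyond the scatter (a 1.2-fold higher number from compound 2 to compound 3 (0.07 log units; within the scatter)). The place therefore takes a group of 5 heavy atoms as well as one of 3, and compound 3 stays with compound 2 at the low end of the series. Nothing measured here explains why the two groups read alike.

Still open, going by these compounds, is how a morpholine, a pyrrolidine or a longer chain in place of the 2-(diethylamino)ethyl group would read. Also open, on these data alone, is whether diethylamino reads the same with methyl in place of isopropoxy on the carbonyl carbon.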